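This account rests on a few compounds, and the source may have more. Where it says the series, first, only, none or still open, it means among the compounds named here.

Measured so far:
- compound 1, `CNC(=O)c1cc(C(=O)NC2CC2)c(C)n(Cc2ccccc2)c1=O`: 577 ug/mL
- compound 2, `CNC(=O)c1cc(C(=O)NC2CC2)cn(Cc2ccc3nc[nH]c3c2)c1=O`: 225 ug/mL
- compound 3, `CNC(=O)c1cc(C(=O)NC2CC2)cn(Cc2cccc3[nH]ccc23)c1=O`: 17 ug/mL

In a physicochemical assay for solubility, read by HPLC, in simulated intestinal fluid, with a stated time of 16 h, tested at 125 ug/mL (a higher number here means a more soluble compound, a lower number a less soluble compound), compound 3 stands lowest of the three numbers. Among the compounds with values here, its nearest neighbour is compound 2, and the single measured step, a 13-fold lower number from compound 2 to compound 3 (1.12 log units; beyond the scatter), separates them. Within the data shown here, compound 1, which carries a plain benzyl group and differs from the other two in more than one place, shows the highest number, so no single step to it can be read off.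

Compound 4, `CNC(=O)c1cc(C(=O)NC2CC2)cn(Cc2cccc(F)c2)c1=O`, is obtained from compound 3 by one change: 3-fluorophenyl in place of 1H-indol-4-yl on a saturated chain carbon bound to an aromatic nitrogen. Among the measured compounds shown here, the only step that bears on this move is the one from compound 2 to compound 3, where a two-ring group with one hydrogen-bond donor was swapped for another, and the number fell by a large amount. Here the two-ring group leaves altogether and a single six-membered ring with no donor enters, which brings compound 4 closer in shape to compound 1. The expected step is therefore a rise, a 16-fold higher number from compound 3 to compound 4 (1.22 log units; beyond the scatter), well beyond the scatter. Compound 4 is estimated at 280 ug/mL, with a range from 100 ug/mL to 600 ug/mL.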

Compound 4, solubility: 31 ug/mL
The estimate for compound 4 lay 9.0-fold (0.96 log units) above the measured number, outside the stated range (below it).
By their numbers in this assay, from the lowest: compounds 3 and 4 (each within the scatter of the next); then compound 2; then compound 1.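

In this assay, replacing 1H-indol-4-yl with 3-fluorophenyl on a saturated chain carbon bound to an aromatic nitrogen gives a 1.8-fold higher number from compound 3 to compound 4 (0.26 log units; within the scatter), so these two quite different groups cannot be told apart at this place. Replacing 1H-benzimidazol-6-yl with 3-fluorophenyl gives a 7.3-fold lower number from compound 2 to compound 4 (0.86 log units; beyond the scatter), which, together with a 13-fold lower number from compound 2 to compound 3 (1.12 log units; beyond the scatter), sets 1H-benzimidazol-6-yl apart from the other two groups at this place, and a single-ring group does not by itself restore the higher number. No measurement here explains this difference.

Compound 1 differs from the other compounds in more than one place, so the contributions of its core methyl and its unsubstituted phenyl cannot be separated. Going by these compounds, how an aminomethyl group or a carboxylic acid on the ring at this place would read in this assay also remains open.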